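Hydroxy in place of methoxymethoxy: expected step from compound 2

A few compounds are considered here, and "the series" means these few. Any claim that something is new, unique, unknown or untested is made for them only; others in the source may bear on it.

Compound 1 `C=C[C@@H]1C[C@@H](Cc2ccc(OC)c(O)c2)[C@H]2C(=O)C=CC(=C)[C@H]21`: 1.17 nM
Compound 2 `C=C1C=CC(=O)[C@@H]2[C@H](Cc3ccc(OCOC)c(F)c3)CC[C@H]12`: 77.2 nM
Compound 3 `C=C1C=CC(=O)[C@@H]2[C@H](Cc3ccccc3)CC[C@H]12`: 260 nM

In a functional assay on MCF7 cells (Homo sapiens) for antiproliferative activity, with a stated time of 72 h (on this read-out lower numbers stand for stronger inhibition and higher numbers for weaker inhibition), compound 2 has the second highest of the three numbers, with compound 3 higher and compound 1 lower, both gaps beyond the usual scatter. Compound 4 `C=C1C=CC(=O)[C@@H]2[C@H](Cc3ccc(O)c(F)c3)CC[C@H]12` departs from compound 2 in one place: hydrogen in place of methoxymethyl on an oxygen on an aromatic ring, with methoxymethoxy becoming hydroxy on the aromatic ring. Going by the values given here, no measured pair isolates this change, so the evidence is indirect. Compound 1 also carries a hydroxy on an aromatic ring and gives 1.17 nM, but it differs from compound 2 in other places too, so it suggests a direction and does not fix a size. A lower number beyond the scatter is therefore expected in this assay, though a smaller drop than the full gap down to compound 1. The step expected is a 6.4-fold lower number from compound 2 to compound 4 (0.81 log units; beyond the scatter). The estimate for compound 4 is 12 nM, with an expected range of 3 nM to 50 nM.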

Compound 4, half-maximal inhibitory concentration: 147 nM
The estimate for compound 4 lay 12-fold (1.09 log units) below the measured number; the measured number lies above the stated range.
By their numbers in this assay, from the lowest: compound 1; then compounds 2, 4 and 3 (each within the scatter of the next, the first and the last beyond it).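

In this assay replacing methoxymethoxy with hydroxy on the aromatic ring gives a 1.9-fold higher number from compound 2 to compound 4 (0.28 log units; within the scatter), so this exchange at this oxygen does not separate the two compounds on this read-out. The hydroxy on the aromatic ring of compound 1 therefore cannot, on this evidence, be read as enough by itself to account for the value of compound 1, which differs from compound 4 in other places too. No measurement shown offers an explanation for this result.

From the compounds shown here alone, whether a longer chain such as butyl on this oxygen, or an amine in place of the hydroxy, would separate from compound 4 remains open. Also open, going by these compounds, is whether the same exchange would give a similar step on the core of compound 1.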